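The source may report more compounds than this note shows. Statements on the series, on what has been measured and on what is new or still open speak of the compounds shown alone.

Measured compounds:
Compound 1, `CN1CCN(c2cn(S(=O)(=O)c3ccccc3)c3ccccc23)CC1`, gives 4 nM in an assay on isolated protein for displacement of a labelled ligand from 5-hydroxytryptamine receptor 6 (Homo sapiens), read by scintillation counting, with a stated time of 1 h; on this read-out lower numbers stand for stronger inhibition and higher numbers for weaker inhibition.
Compound 2, `CC(=O)N1CCN(c2cn(S(=O)(=O)c3ccccc3)c3ccccc23)CC1`, gives 97 nM.
Compound 3, `CN1CCN(c2cccc3c2ccn3S(=O)(=O)c2ccccc2)CC1`, gives 1 nM.

Compound 2 differs from compound 1 by acetyl in place of methyl on an amine nitrogen in a ring, and this brought a 24-fold higher number from compound 1 to compound 2 (1.38 log units; beyond the scatter). Compound 3 is built on a different core from compound 1; the difference between the two cores is not broken down here, and compound 3 stands lowest of the three numbers, with compound 1 nearest and compound 2 furthest.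

Compound 4, `CC(=O)N1CCN(c2cccc3c2ccn3S(=O)(=O)c2ccccc2)CC1`, carries the same change on the core of compound 3: acetyl in place of methyl on an amine nitrogen in a ring. The same change in the same place is expected to give a step of about the same size as a 24-fold higher number from compound 1 to compound 2 (1.38 log units; beyond the scatter), which rests on that single pair. Compound 4 is therefore estimated at 24 nM, likely between 8 nM and 70 nM. That estimate corresponds to an expected step of a 24-fold higher number from compound 3 to compound 4 (1.38 log units; beyond the scatter).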

Compound 4, inhibition constant: 714 nM
Beside the measured number, compound 4's estimate is 30-fold (1.47 log units) below it; the measured number lies above the stated range.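

In this assay, acetyl in place of methyl on an amine nitrogen in a ring brought a 710-fold higher number from compound 3 to compound 4 (2.85 log units; beyond the scatter). The change raised the number on both cores, but the size of the step did not carry over from one core to the other: the same change on two cores in this assay, a 24-fold higher number (1.38 log units; beyond the scatter) from compound 1 to compound 2 and a 710-fold higher number (2.85 log units; beyond the scatter) from compound 3 to compound 4, 29-fold (1.47 log units) apart, beyond the scatter of two such steps. So the direction held in these two pairs while the size differed with the core, but two pairs cannot show how large the step would be on a further core, or which part of the difference between the cores goes with the larger step.

On these data alone, it remains open how an ethyl group or a longer chain in place of methyl on that nitrogen would fare on each core. As far as these compounds go, it also remains open whether the gap between the cores would persist with a carboxamide or a sulfonyl group there.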